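Urea aryl swap in a chloro-nicotinamide oxadiazole series

This account rests on a few compounds, and the source may have more. Where it says the series, first, only, none or still open, it means among the compounds named here.

Measured compounds and their values in a functional assay on MDA-MB-231 cells (Homo sapiens) for antiproliferative activity, read by MTT assay, with a stated time of 72 h; on this read-out higher numbers stand for weaker inhibition and lower numbers for stronger inhibition:
compound 1 `O=C(Nc1cccc(-c2nc(-c3ccc(NC(=O)c4cccnc4)cc3Cl)no2)c1)c1ccccc1` — 12800 nM
compound 2 `COc1ccc(NC(=O)Nc2cccc(-c3nc(-c4ccc(NC(=O)c5cccnc5)cc4Cl)no3)c2)cc1` — 3000 nM
compound 3 `O=C(Nc1cccc(-c2nc(-c3ccc(NC(=O)c4cccnc4)cc3Cl)no2)c1)Nc1ccc(Cl)c(C(F)(F)F)c1` — 1900 nM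

Compound 3 gives the lowest number of the three in this assay; the gap to compound 2 is within the scatter, so the two cannot be ordered, while the step of a 6.7-fold lower number from compound 1 to compound 3 (0.83 log units; beyond the scatter) lies beyond the scatter.

Compound 4 `NS(=O)(=O)Nc1ccc(NC(=O)Nc2cccc(-c3nc(-c4ccc(NC(=O)c5cccnc5)cc4Cl)no3)c2)cc1` differs from compound 3 by 4-(sulfamoylamino)phenyl in place of 4-chloro-3-(trifluoromethyl)phenyl on an amide-type nitrogen. Among the compounds with values here, the one measured step on the same nitrogen, a 1.6-fold lower number from compound 2 to compound 3 (0.20 log units; within the scatter), stayed within the scatter, and both steps off compound 1, a 4.3-fold lower number from compound 1 to compound 2 (0.63 log units; beyond the scatter) and a 6.7-fold lower number from compound 1 to compound 3 (0.83 log units; beyond the scatter), turn on the urea itself, which compound 4 keeps. Nothing measured speaks to the sulfamoylamino group. The expected step is therefore a 1.3-fold higher number from compound 3 to compound 4 (0.12 log units; within the scatter), within the scatter; compound 4 is estimated at 2500 nM, range 900 nM to 7000 nM.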

Compound 4, half-maximal inhibitory concentration: 8900 nM
Beside the measured number, compound 4's estimate is 3.6-fold (0.55 log units) below it; measured number outside the range, above it.
By their numbers in this assay, from the lowest: compounds 3 and 2 (each within the scatter of the next); then compounds 4 and 1 (each within the scatter of the next).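

On this amide-type nitrogen the aryl group is not interchangeable in this assay, since a 4.7-fold higher number from compound 3 to compound 4 (0.67 log units; beyond the scatter) and a 3.0-fold higher number from compound 2 to compound 4 (0.47 log units; beyond the scatter) both lie beyond the scatter, which the earlier swap of aryl groups did not. With a 1.4-fold lower number from compound 1 to compound 4 (0.16 log units; within the scatter) inside the scatter, the urea alone does not secure the lower numbers of compound 2 and compound 3. No measurement here explains the rise with the sulfamoylamino group.

Open, on these data alone, is whether an amine or a carboxylic acid in place of sulfamoylamino on the aromatic carbon would read like compound 2 or like compound 4.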